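The source may report more compounds than this note shows. Statements on the series, on what has been measured and on what is new or still open speak of the compounds shown alone.

Compound 1 `C#CCn1c(-c2ccc(Cl)cc2)cc(-c2ccc(Cl)cc2)c(C#N)c1=O` gives 18.3 ug/mL. Compound 2 `N#Cc1c(-c2ccc(Cl)cc2)cc(-c2ccc(Cl)cc2)n(CC2CO2)c1=O` gives 6.2 ug/mL. Compound 3 `C=CCn1c(-c2ccc(Cl)cc2)cc(-c2ccc(Cl)cc2)c(C#N)c1=O` gives 20 ug/mL.

In a functional assay on HepG2 cells (Homo sapiens) for cytotoxicity, read by sulforhodamine B assay, with a stated time of 48 h (a higher number here means a weaker inhibitor, a lower number a stronger inhibitor), compound 3 holds the highest of the three numbers. The step of a 1.1-fold higher number from compound 1 to compound 3 (0.04 log units; within the scatter) lies within the scatter, whereas a 3.2-fold higher number from compound 2 to compound 3 (0.51 log units; beyond the scatter) lies beyond it, so only compound 2 stands apart from compound 3. Compound 4 `N#Cc1c(-c2ccc(Cl)cc2)cc(-c2ccc(Cl)cc2)n(CC(O)CCl)c1=O` differs from compound 3 in one place: 2-chloro-1-hydroxyethyl in place of vinyl on a saturated chain carbon bound to an aromatic nitrogen. Going by the values given here, no measured step makes this exact change. The step that bears on it most is a 3.2-fold higher number from compound 2 to compound 3 (0.51 log units; beyond the scatter), since oxiran-2-yl and 2-chloro-1-hydroxyethyl both replace vinyl on the same chain carbon, and that step was modest. A modest lower number is therefore expected for compound 4, near compound 2, as a 2.5-fold lower number from compound 3 to compound 4 (0.40 log units; beyond the scatter). The estimate for compound 4 is 8 ug/mL, between 4 ug/mL and 16 ug/mL.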

Compound 4, half-maximal inhibitory concentration: 4.8 ug/mL
The estimate for compound 4 lay 1.7-fold (0.22 log units) above the measured number, and the stated range covers the measured number.
By their numbers in this assay, from the lowest: compounds 4 and 2 (each within the scatter of the next); then compounds 1 and 3 (each within the scatter of the next).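

In this assay, the open-chain 2-chloro-1-hydroxyethyl group does not separate from the oxiran-2-yl group, with a 1.3-fold lower number from compound 2 to compound 4 (0.11 log units; within the scatter) lying within the scatter. Both other steps lie beyond the scatter, a 4.2-fold lower number from compound 3 to compound 4 (0.62 log units; beyond the scatter) and a 3.8-fold lower number from compound 1 to compound 4 (0.58 log units; beyond the scatter), so among these compounds the lower number at this position does not depend on keeping the oxirane ring. Nothing available explains these steps.

The compounds shown leave open whether the chlorine is needed for the lower number. On these data alone, an amine in its place, or a longer chain carrying the hydroxyl, remains untested here.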